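A few compounds are considered here, and "the series" means these few. Any claim that something is new, unique, unknown or untested is made for them only; others in the source may bear on it.

The read-out throughout is an assay on HEK293 cells for inhibition of Toll-like receptor 8 (Homo sapiens), with a stated time of 16 h; on this read-out higher numbers stand for weaker inhibition and lower numbers for stronger inhibition. Compound 1 `N#Cc1c(Cl)cccc1Oc1ccc(-c2nnco2)cc1` in this assay gives 1400 nM. Compound 2 `O=C(Nc1ccc(Oc2cc(C(F)(F)F)cc(C(F)(F)F)c2)cc1)c1cc(I)ccc1F` rests on a different core from compound 1, and in this assay compound 2 gives "not determined" (no result reported): there is no single number, and nothing can be said about where it stands on the scale. Compound 3 `O=C(Nc1ccc(Oc2cc(C(F)(F)F)cc(C(F)(F)F)c2)cc1)c1ccc(O)cc1F` differs from compound 2 in one place: 2-fluoro-4-hydroxyphenyl in place of 2-fluoro-5-iodophenyl on a carbonyl carbon. A group with no hydrogen-bond donor or acceptor gives way to one that carries one of each. Among the measured compounds shown here, no measured pair in this set shows an exchange of this kind, and compound 2 itself offers no value to build on; the only anchor is compound 1, which has another core. The expectation for this step is open in both directions, with no preferred size. Compound 3 is expected to give about 600 nM in this assay, within a range from 60 nM to 6000 nM.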

Compound 3, half-maximal inhibitory concentration: > 50000 nM
Compound 3 gave a limit, no number; the forecaster's own chance of this, stated with the estimate: 15%; middle value at least 83-fold (1.92 log units) from the limit.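

In this assay compound 3 gives > 50000 nM, which is a limit of the assay and not a number. Compound 2 has no reported result, so no step can be read between compound 2 and compound 3. Going by these compounds, what the exchange of 2-fluoro-5-iodophenyl for 2-fluoro-4-hydroxyphenyl does to inhibition stays open.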